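Methyl for phenyl on the amide-type nitrogen of compound 1

A few compounds are considered here, and "the series" means these few. Any claim that something is new, unique, unknown or untested is made for them only; others in the source may bear on it.

- compound 1 `CS(=O)(=O)c1ccc(C(=O)N2CCC(C(=O)N(Cc3ccccc3)c3ccccc3)CC2)cc1[N+](=O)[O-]`: > 27000 nM
- compound 2 `CN(Cc1cccc(F)c1)C(=O)CCCNC(=O)c1ccc(S(C)(=O)=O)c([N+](=O)[O-])c1`: > 27000 nM
- compound 3 `CS(=O)(=O)c1ccc(C(=O)NCCC(=O)N2CCc3ccccc32)cc1[N+](=O)[O-]`: > 27000 nM

Compound 1 gives only a limit in an ADME assay on HepG2 cells (Homo sapiens) for cytotoxicity, read by CellTiter-Glo and ATP content, with a stated time of 72 h (on this read-out lower numbers stand for an effect already at smaller amounts and higher numbers for an effect only at larger amounts of compound), namely > 27000 nM, and not a number. The whole set shares one reading (the limit of > 27000 nM in this assay, at which 3 of the 3 values shown sit). Compound 4 `CN(Cc1ccccc1)C(=O)C1CCN(C(=O)c2ccc(S(C)(=O)=O)c([N+](=O)[O-])c2)CC1` has methyl in place of phenyl on an amide-type nitrogen. No measured pair sizes this change in this assay, and no step beyond the usual scatter is expected. Compound 2 (> 27000 nM), also a limit, already carries methyl on an amide-type nitrogen, which supports that expectation. The expected change is small (a step that the limit leaves unreadable from compound 1 to compound 4). For compound 4 the estimated value is 30000 nM, with an expected range from 15000 nM to 60000 nM, most likely reported as a limit again.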

Compound 4, half-maximal effective concentration: > 27000 nM
Compound 4: no number, only a limit; the forecaster's own chance of this, stated with the estimate: 85%; the middle value does not contradict the limit.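

Compound 1 and compound 4 both give only a limit, so no step can be read between them: the limit of > 27000 nM in this assay, at which 4 of the 4 values shown sit.

The compounds shown leave open the size of the methyl-for-phenyl change and which structural change, if any, would give a readable number.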